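Capping the Piperidine Nitrogen: What Clearance to Expect

A few compounds are considered here, and "the series" means these few. Any claim that something is new, unique, unknown or untested is made for them only; others in the source may bear on it.

Compound 2 `CC(C)n1cc(-c2ccnc3[nH]c(C4CCNCC4)cc23)ccc1=O` carries an unsubstituted amine nitrogen in a ring on the shared core. In an ADME assay on cells (Hepatocyte, Rattus norvegicus) for metabolic stability (on this read-out higher numbers stand for fast clearance and lower numbers for slow clearance), compound 2 gives < 1 uL/min, which is a limit of the assay rather than a number (the limit of < 1 uL/min in this assay, at which 1 of the 3 values shown sits). Compound 1 `CN(C)C(=O)CN1CCC(c2cc3c(-c4ccc(=O)n(C5CCC5)c4)ccnc3[nH]2)CC1` and compound 3 `CN(C)C(=O)CN1CCC(c2cc3c(-c4ccc(=O)n(CCC5CCOCC5)c4)ccnc3[nH]2)CC1` both carry a group on that ring nitrogen in place of hydrogen. In this assay compound 1 gives 5.8 uL/min and compound 3 gives 14 uL/min. Going by the values given here, the only measured step, a 2.4-fold higher number from compound 1 to compound 3 (0.38 log units; beyond the scatter), alters the substituent on the aromatic nitrogen and does not touch the site changed here. Compound 4 `CC(C)n1cc(-c2ccnc3[nH]c(C4CCN(CC(=O)N5CCCC5)CC4)cc23)ccc1=O` differs from compound 2 by ((pyrrolidin-1-yl)carbonyl)methyl in place of hydrogen on an amine nitrogen in a ring. Among the compounds with values here, no measured step covers this change; compounds 1 and 3 merely show that substituted analogues give numbers rather than a limit. Compound 4 is therefore expected to move upward, an at least 5.0-fold higher number from compound 2 to compound 4 (0.69 log units; beyond the scatter), with an estimated value of 5 uL/min spanning 1.5 uL/min to 15 uL/min.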

Compound 4, intrinsic clearance in a liver preparation (reported as CLH), per the amount of preparation that the assay uses: 5.4 uL/min
The estimate for compound 4 lay 1.1-fold (0.03 log units) below the measured number; the range from low to high includes it.
By their numbers in this assay, from the lowest: compounds 4 and 1 (each within the scatter of the next); then compound 3. At a limit, below all of these: compound 2.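

In this assay, going by these compounds alone, ((pyrrolidin-1-yl)carbonyl)methyl in place of hydrogen on the amine nitrogen in a ring gives the first measured step at this position, an at least 5.4-fold higher number from compound 2 to compound 4 (0.73 log units; beyond the scatter). The step has only a lower bound because compound 2 stands at a limit of the assay and not at a number: the limit of < 1 uL/min in this assay, at which 1 of the 4 values shown sits.

The compounds shown leave open whether a simple methyl, a longer chain ending in an amine, or a carboxylic acid on this nitrogen would raise the number as far. They also leave open how far above the limit compound 2 would need to lie to change the size of this step.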